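A few compounds are considered here, and "the series" means these few. Any claim that something is new, unique, unknown or untested is made for them only; others in the source may bear on it.

Measured compounds:

Compound 1 `CN1c2ccc(NC(=S)Nc3ccc([N+](=O)[O-])cc3)cc2C(C)(C)C(O)C1(C)C`, in an assay on isolated protein for binding affinity to stress-70 protein, mitochondrial (Homo sapiens); on this read-out lower numbers stand for tighter binding and higher numbers for weaker binding: 2300 nM
Compound 2 `CN1c2ccc(NC(=S)Nc3ccc(C(F)(F)F)cc3)cc2C(C)(C)C(O)C1(C)C`, in this assay: 2300 nM
Compound 3 `CN1c2ccc(NC(=S)Nc3ccc(OC(F)(F)F)cc3)cc2C(C)(C)C(O)C1(C)C`, in this assay: 2900 nM

Compound 1 stands level with compound 2 at the digits shown, the two together giving the lowest numbers of the three, and compound 3 is nearest-furthest with a difference that still lies within the scatter. The three measured steps all concern the substituent on the aromatic carbon: no change at the digits printed from compound 1 to compound 2 (within the scatter), a 1.3-fold higher number from compound 1 to compound 3 (0.10 log units; within the scatter) and a 1.3-fold higher number from compound 2 to compound 3 (0.10 log units; within the scatter). None of them is larger than the scatter.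

Compound 4 `CN1c2ccc(NC(=S)Nc3ccc([N+](=O)[O-])cc3)cc2C(C)(C)CC1(C)C` differs from compound 1 in another place altogether: hydrogen in place of hydroxy on a saturated ring carbon. Within the data shown here, no measured step touches this saturated ring carbon of the shared core, so the three aryl-substituent steps give no direct guidance on how this assay will respond. With nothing in the data pointing in either direction, the expected step is a 1.1-fold higher number from compound 1 to compound 4 (0.04 log units; within the scatter), that is none beyond the scatter, though the uncertainty is wide. Compound 4 is therefore estimated at 2500 nM, with a range from 700 nM to 9000 nM.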

Compound 4, dissociation constant: 500 nM
For compound 4 the middle estimate is 5.0-fold (0.70 log units) above the measured one, and the stated range ends above it.
By their numbers in this assay, from the lowest: compound 4; then compounds 1, 2 and 3 (each within the scatter of the next).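

In this assay, the saturated ring carbon of the shared core responds where the substituent on the aromatic carbon did not: hydrogen in place of hydroxy gives a 4.6-fold lower number from compound 1 to compound 4 (0.66 log units; beyond the scatter), the only step among these compounds that lies beyond the scatter. Since lower numbers stand for tighter binding, the hydroxy is not required for binding in this pair, and the compound without it binds more tightly. Nothing in the information at hand explains this step.

Among these compounds, this change is seen only with nitro on the aromatic carbon, so it remains open whether it carries over to the trifluoromethyl and trifluoromethoxy compounds. Also open, from the compounds shown here alone, is how this assay would respond to other groups on the saturated ring carbon, such as a methoxy, an amine or a carbonyl.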